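A few compounds are considered here, and "the series" means these few. Any claim that something is new, unique, unknown or untested is made for them only; others in the source may bear on it.

In a functional assay on CHO cells for positive allosteric modulation of metabotropic glutamate receptor 2 (Homo sapiens), read by scintillation counting and GTPgammaS binding, with a stated time of 30 min (a lower number here means a smaller maximal response, a higher number a larger maximal response), the three measured compounds give these maximal responses:

compound 1 `COc1ccc(-c2ccn(CCC(C)C)c(=O)c2C#N)cc1Cl` gives 200%
compound 2 `CC(C)CCn1ccc(-c2ccc(OCC3CC3)cc2)c(C#N)c1=O` gives 192%
compound 3 `CC(C)CCn1ccc(-c2ccc(OCC3CC3)c(Cl)c2)c(C#N)c1=O` gives 206%

Compound 3 has the highest of the three numbers, yet only one of the two gaps below it is a real one. The step of a number 6 percentage points higher from compound 1 to compound 3 (within the scatter) lies inside the scatter, so compounds 1 and 3 cannot be told apart. The step of a number 14 percentage points higher from compound 2 to compound 3 (beyond the scatter) is modest but real.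

Compound 4 `CC(C)CCn1ccc(-c2ccc(OC3CCCC3)c(Cl)c2)c(C#N)c1=O` is not yet measured. It differs from compound 3 in one place: cyclopentyl in place of cyclopropylmethyl on an oxygen on an aromatic ring. Going by the values given here, the only measured step that touches the group on that oxygen is a number 6 percentage points higher from compound 1 to compound 3 (within the scatter), and it stayed within the scatter. The other step, a number 14 percentage points higher from compound 2 to compound 3 (beyond the scatter), concerns the chloro group, which compound 4 keeps, so it says little here. Exchanging one small carbon ring for another on the same oxygen is therefore expected to give a step of about a number 6 percentage points lower from compound 3 to compound 4 (within the scatter), that is, none beyond the scatter. Compound 4 is estimated to reach 200%, with a range from 175% to 225%.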

Compound 4, largest response reached (Emax), in percent of the reference or control that the assay uses: 199%
Compound 4: middle estimate off by 1 percentage points, on the high side, within the range that was stated.
By their numbers in this assay, from the lowest: compounds 2, 4, 1 and 3 (each within the scatter of the next, the first and the last beyond it).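

On the oxygen on the aromatic ring, the change from cyclopropylmethyl to cyclopentyl, a five-membered carbon ring, gives a number 7 percentage points lower from compound 3 to compound 4 (within the scatter) in this assay and so leaves the maximal response indistinguishable. The comparison with the much smaller methyl group gives a number 1 percentage points lower from compound 1 to compound 4 (within the scatter) and points the same way: with the chloro group kept, methyl, cyclopropylmethyl and cyclopentyl on this oxygen cannot be told apart, so this position accepts all three in this read-out. No measurement shown here bears on why the response holds across these groups.

All three groups contain only carbon and hydrogen, so an amine, a carboxylic acid or a longer chain carrying a hydroxyl group on the same oxygen remains untested in what is shown. On these data alone, whether a still bulkier group, such as a phenyl or cyclohexyl ring, would keep this response also stays open.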